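The source may hold more compounds than are shown below. What is called first, only, known or untested is meant among the compounds shown, and "the series" means these compounds.

Measured in a functional assay on SW-620 cells (Homo sapiens) for cytotoxicity, read by MTT assay, with a stated time of 72 h; on this read-out higher numbers stand for weaker inhibition and lower numbers for stronger inhibition:
Compound 1 `COc1cccc(/C=C2\CCC/C(=C\c3ccc(Cl)cc3)C2=O)c1OC`: 11100 nM
Compound 2 `COc1ccc(/C=C2\CCC/C(=C\c3cccc(Br)c3)C2=O)cc1OC`: 4200 nM

Compound 2 holds the lower of the two numbers, at 4200 nM, and so shows the stronger inhibition; the gap up to compound 1 lies beyond the scatter. The next compound to be tested is compound 3 `COc1ccc(/C=C2\CCC/C(=C\c3ccc(Cl)cc3Cl)C2=O)cc1OC`, which departs from compound 2 in one place: 2,4-dichlorophenyl in place of 3-bromophenyl on a double-bonded chain carbon bound to a double-bonded ring carbon. That is 2,4-dichlorophenyl in place of 3-bromophenyl on a double-bonded chain carbon bound to a double-bonded ring carbon. For the measured compounds named here, no measured pair isolates a change in one place, so the expectation rests on compound 2 at 4200 nM as its starting point. In this assay, the expected outcome is a 1.2-fold higher number from compound 2 to compound 3 (0.08 log units; within the scatter), which stays within the scatter and has no firm direction. For compound 3 the estimate is 5000 nM, with an expected range from 1800 nM to 14000 nM.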

Compound 3, half-maximal inhibitory concentration: 10300 nM
The estimate for compound 3 lay 2.1-fold (0.31 log units) below the measured number; the measured number falls inside the stated range.
By their numbers in this assay, from the lowest: compound 2; then compounds 3 and 1 (each within the scatter of the next).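

In this assay, for the compounds shown here, the exchange of 3-bromophenyl for 2,4-dichlorophenyl on a double-bonded chain carbon bound to a double-bonded ring carbon gives a 2.5-fold higher number from compound 2 to compound 3 (0.39 log units; beyond the scatter) and is the first change here isolated in one place. It shows that this position is not indifferent to which halogen-bearing phenyl it carries, even though both groups have one six-membered aromatic ring of carbon only and neither has a hydrogen-bond donor or acceptor. Nothing available explains the loss of inhibition.

This single step changes the halogen and its substitution pattern together, so the contribution of each remains unresolved. Also open, as far as these compounds go, is how this position would respond to an unsubstituted phenyl or to a phenyl bearing an amine or a carboxylic acid.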